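Pyridyl to Fluorophenyl on the Amino-Pyrimidine Core

The source may hold more compounds than are shown below. What is called first, only, known or untested is meant among the compounds shown, and "the series" means these compounds.

Measured compounds:
compound 1 `O=C(NCCCNc1nc(Nc2cccnc2)ncc1C1CC1)C1CCC1`: 13 nM
compound 2 `COCCC(=O)NCCCNc1nc(Nc2cccc(F)c2)ncc1Br`: 60 nM

In an assay on isolated protein for inhibition of serine/threonine-protein kinase TBK1 (Homo sapiens) (on this read-out higher numbers stand for weaker inhibition and lower numbers for stronger inhibition), compound 1 gives 13 nM, the lowest of the two numbers. Compound 2 gives 60 nM, a gap that lies beyond the usual scatter, but the two structures differ in several places at once, so their values alone cannot be traced to any single change.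

Compound 3 `O=C(NCCCNc1nc(Nc2cccc(F)c2)ncc1C1CC1)C1CCC1` differs from compound 1 in one place only: 3-fluorophenyl in place of pyridin-3-yl on a nitrogen on an aromatic ring. Going by the values given here, no measured pair shows this change by itself. Compound 2 carries the same 3-fluorophenyl group, yet its other differences from compound 1 keep it from serving as a direct guide. The step is expected to be small, at most a slight weakening, and likely within the scatter of this assay. Compound 3 is therefore estimated at 20 nM, with a range of 8 nM to 55 nM, the expected step from compound 1 to compound 3 being a 1.5-fold higher number from compound 1 to compound 3 (0.19 log units; within the scatter).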

Compound 3, half-maximal inhibitory concentration: 8 nM
The estimate for compound 3 lay 2.5-fold (0.40 log units) above the measured number; low and high end bracket the measured number.
By their numbers in this assay, from the lowest: compounds 3 and 1 (each within the scatter of the next); then compound 2.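

In this assay, 3-fluorophenyl in place of pyridin-3-yl on a nitrogen on an aromatic ring gives a 1.6-fold lower number from compound 1 to compound 3 (0.21 log units; within the scatter), so this change leaves compound 1 and compound 3 indistinguishable on this read-out. Pyridin-3-yl counts a hydrogen-bond acceptor and 3-fluorophenyl counts none, yet with the rest of the structure held constant, the exchange produces no step beyond the scatter. No independent measurement here offers an explanation for this result.

On these data alone, it remains open how a phenyl ring without fluorine, or one bearing an amine or a carboxylic acid, would read in this place. Also open, as far as these compounds go, is what the bromine and the 3-methoxypropanoyl group of compound 2 each contribute to its value, since these appear together and cannot be separated.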